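This account rests on a few compounds, and the source may have more. Where it says the series, first, only, none or still open, it means among the compounds named here.

Compound 1 `CCCn1c(=O)c2nc(-c3cnn(Cc4cc(F)ccc4Cl)c3)[nH]c2n(CCC)c1=O` carries a 2-chloro-5-fluorobenzyl group on the shared core, and in an assay on CHO cells for displacement of a labelled ligand from adenosine receptor A1 (Homo sapiens) (on this read-out higher numbers stand for weaker inhibition and lower numbers for stronger inhibition), compound 1 has "not determined" (no result reported) as its entry, so it offers no anchor of its own. Two related compounds do have numbers. Compound 2 `CCCn1c(=O)c2[nH]c(-c3cnn(Cc4ccccc4)c3)nc2n(CCC)c1=O` gives 76 nM in this assay. Compound 3 `Cn1c(=O)c2[nH]c(-c3cnn(Cc4cccc(F)c4)c3)nc2n(C)c1=O` gives 460 nM in this assay; it differs from compound 2 in more than one place, so these two values show only where this chemical family tends to sit. Compound 4 `CCCn1c(=O)c2nc(-c3cnn(Cc4ccccc4C)c3)[nH]c2n(CCC)c1=O` is the next member, and the change from compound 1 to compound 4 is 2-methylphenyl in place of 2-chloro-5-fluorophenyl on a saturated chain carbon bound to an aromatic nitrogen. Because compound 1 has no number, the direction of that step cannot be read from data; the expectation is that the swap of one benzyl substituent pattern for another moves the result only modestly, likely within the usual scatter. Compound 4 shares its propyl chains with compound 2, whose 76 nM is the closest guide, so compound 4 is expected to give about 110 nM, with a likely range from 30 nM to 400 nM.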

Compound 4, inhibition constant: 22 nM
Estimate against measurement, compound 4: 5.0-fold (0.70 log units) above, outside the stated range (below it).
By their numbers in this assay, from the lowest: compound 4; then compound 2; then compound 3.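

No new step can be read from compound 4 alongside compound 1, compound 2 and compound 3. As far as these compounds go, how the change from 2-chloro-5-fluorobenzyl to 2-methylbenzyl acts in this assay stays open. No measurement shown offers an explanation for the result of compound 4.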